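A few compounds are considered here, and "the series" means these few. Any claim that something is new, unique, unknown or untested is made for them only; others in the source may bear on it.

Measured so far in a functional assay on MDA-MB-231 cells (Homo sapiens) for inhibition, read by MTT assay, with a stated time of 72 h, tested at 20 uM; on this read-out higher numbers stand for more inhibition at the one concentration tested (going by the name of the read-out) and lower numbers for less inhibition:

- compound 2, `c1cc(N2CCCCC2)nc(Nc2ccc(Oc3ncnc4sccc34)cc2)n1`, gives 40.4%
- compound 3, `c1cc(N2CCCCC2)nc(Nc2ccc(Oc3ncnc4ccsc34)cc2)n1`, gives 45.7%
- compound 1, `CN(c1ccc(Oc2ncnc3sccc23)cc1)c1nccc(N2CCc3ccccc3C2)n1`, gives 24.3%

Going by the values given here, compound 2 sits second highest of the three numbers; its nearest neighbour is compound 3, and the only one-place step between measured compounds, a number 5.3 percentage points higher from compound 2 to compound 3 (within the scatter), stays within the scatter. Compound 1 lies furthest from compound 2, beyond the scatter.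

Compound 4, `c1ccc2c(c1)CCN(c1ccnc(Nc3ccc(Oc4ncnc5sccc45)cc3)n1)C2`, differs from compound 2 as follows: 1,2,3,4-tetrahydroisoquinolin-2-yl in place of piperidin-1-yl on an aromatic carbon. Among the compounds with values here, the single measured step concerns the ring system on the ether oxygen, not the amine on the shared core, so it does not bear on this change; no measured pair isolates the exchange of piperidin-1-yl for 1,2,3,4-tetrahydroisoquinolin-2-yl alone. Compound 1 carries the same 1,2,3,4-tetrahydroisoquinolin-2-yl and an additional methyl, and its value of 24.3% sits beyond the scatter under compound 2, but that comparison mixes two changes. The step of a number 4.4 percentage points lower from compound 2 to compound 4 (within the scatter) is therefore expected to be small and uncertain in direction. Compound 4 is estimated at 36% in this assay, between 18% and 56%.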

Compound 4, a percentage reported as inhibition, at one concentration (the size of the read-out at that concentration, not a potency): 26.8%
The estimate for compound 4 lay 9.2 percentage points above the measured number; low and high end bracket the measured number.
By their numbers in this assay, from the lowest: compounds 1 and 4 (each within the scatter of the next); then compounds 2 and 3 (each within the scatter of the next).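

In this assay the exchange of piperidin-1-yl for 1,2,3,4-tetrahydroisoquinolin-2-yl on the aromatic carbon next to the ring nitrogen can now be read alone, as a number 13.6 percentage points lower from compound 2 to compound 4 (beyond the scatter) on an otherwise unchanged structure. Hydrogen in place of methyl on the nitrogen on the aromatic ring gives a number 2.5 percentage points higher from compound 1 to compound 4 (within the scatter) and so leaves no difference that can be told from the scatter for that change. Nothing at hand gives a reason for either step.

On these data alone, whether a morpholine ring or an open-chain amine such as diethylamino on the same carbon would stand nearer to compound 2 or to compound 4 stays open. Also open, as far as these compounds go, is whether the same exchange on the core of compound 3 would give a step of like size.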